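Swapping the Benzyl Group: From Bromine to Methoxy

The compounds below may be only part of what the source reports. "The series", "measured", "known", "first", "only" and "open" are said of these compounds alone.

Compound 1 `O=S(=O)(NCCCNCC1COc2ccccc2O1)c1cc(C(F)(F)F)cc(C(F)(F)F)c1` gives 3400 nM in a functional assay on PANC-1 cells (Homo sapiens) for inhibition, read by MTT assay, with a stated time of 72 h; a higher number here means a weaker inhibitor of growth, a lower number a stronger inhibitor of growth.
Compound 2 `O=S(=O)(NCCCNCc1ccc(Br)cc1)c1cc(C(F)(F)F)cc(C(F)(F)F)c1` gives 2200 nM in this assay.

Compound 2 and compound 1 cannot be told apart here: a 1.5-fold lower number from compound 1 to compound 2 (0.19 log units; within the scatter). Compound 3 `COc1ccccc1CNCCCNS(=O)(=O)c1cc(C(F)(F)F)cc(C(F)(F)F)c1` carries 2-methoxyphenyl in place of 4-bromophenyl on a saturated chain carbon bound to an amine nitrogen. Among the measured compounds shown here, the only measured step is the one from compound 1 to compound 2, which changed a different group on the same chain carbon and stayed within the scatter, so it gives no lead for the direction of the new change. No step beyond the scatter is expected in this assay, and compound 3 is estimated at 2600 nM (range 1000 nM to 7000 nM), meaning an expected 1.2-fold higher number from compound 2 to compound 3 (0.07 log units; within the scatter).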

Compound 3, concentration for 50% growth inhibition: 12000 nM
For compound 3 the middle estimate is 4.6-fold (0.66 log units) below the measured one, outside the stated range (above it).
By their numbers in this assay, from the lowest: compounds 2 and 1 (each within the scatter of the next); then compound 3.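

In this assay the group on this saturated chain carbon turns out to matter, with a 5.5-fold higher number from compound 2 to compound 3 (0.74 log units; beyond the scatter) and also a 3.5-fold higher number from compound 1 to compound 3 (0.55 log units; beyond the scatter). The two earlier groups could not be told apart, yet both give lower numbers than 2-methoxyphenyl, so this position does not accept every aromatic group equally. No measurement here explains the difference.

The compounds shown leave open how a plain phenyl group would read at this place, and so whether the methoxy group or the loss of bromine accounts for the step.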